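Swapping the benzoyl for a pivaloyl on a long-lived sulfone

This account rests on a few compounds, and the source may have more. Where it says the series, first, only, none or still open, it means among the compounds named here.

Measured so far:
compound 1 `CO[C@H]1C(=O)N2C(C(=O)c3ccccc3)=C(C)CS(=O)(=O)[C@H]12`: 33 h
compound 2 `CO[C@H]1C(=O)N2C(C(=O)c3ccccc3)=C(C)C(Sc3nnnn3C)S(=O)(=O)[C@H]12`: 120 h
compound 3 `CO[C@H]1C(=O)N2C(C(=O)C(C)(C)C)=C(CSc3nnc(C)s3)CS(=O)(=O)[C@H]12`: 37 h

In a physicochemical assay for pharmacokinetics, at 37 degrees C (on this read-out higher numbers stand for a longer-lived compound and lower numbers for a shorter-lived compound), compound 2 stands highest of the three; compound 3 is next and compound 1 furthest behind. For the measured compounds named here, the one step with a single change is a 3.6-fold higher number from compound 1 to compound 2 (0.56 log units; beyond the scatter), which concerns a different part of the shared core. Compound 4 `CO[C@H]1C(=O)N2C(C(=O)C(C)(C)C)=C(C)C(Sc3nnnn3C)S(=O)(=O)[C@H]12` differs from compound 2 by tert-butyl in place of phenyl on a carbonyl carbon. Going by the values given here, no measured pair isolates this change: compound 1 and compound 3 carry the two groups but differ in further places. Compound 1 gives 33 h and compound 3 gives 37 h, values that sit within the scatter of each other. Compound 4 is therefore expected to show a 1.1-fold lower number from compound 2 to compound 4 (0.04 log units; within the scatter). Compound 4 is estimated at 110 h, with a range of 55 h to 220 h.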

Compound 4, half-life: 14.8 h
Beside the measured number, compound 4's estimate is 7.4-fold (0.87 log units) above it; measured number outside the range, below it.
By their numbers in this assay, from the lowest: compound 4; then compounds 1 and 3 (each within the scatter of the next); then compound 2.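

In this assay, the group on the carbonyl carbon clearly matters: tert-butyl in place of phenyl gives an 8.1-fold lower number from compound 2 to compound 4 (0.91 log units; beyond the scatter). The earlier compounds shown here held no pair isolating this change, so this step is its first direct reading, and it applies to the core of compound 2 only. Nothing available here explains the size of this step. Still open, going by these compounds, is where a cyclohexyl or a pyridyl group on the same carbonyl carbon would fall relative to compound 2 and compound 4. Also open, on these data alone, is whether the same swap would give a similar step on the core of compound 1.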